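A few compounds are considered here, and "the series" means these few. Any claim that something is new, unique, unknown or untested is made for them only; others in the source may bear on it.

The series is a set of glycosides tested in a functional assay on RAW264.7 cells (Mus musculus) for inhibition; on this read-out higher numbers stand for weaker inhibition and lower numbers for stronger inhibition. Compound 1, `CC1=CC(=O)[C@H]2C[C@]1(O[C@@H]1O[C@H](COC(=O)c3ccccc3)[C@@H](O)[C@H](O)[C@H]1O)C2(C)CO`, carries a benzoyl ester on the sugar; in this assay compound 1 gives > 100000 nM, which is a limit of the assay and not a number. Compound 2, `CC12C(=O)O[C@@]3(C)C[C@@H](O)[C@H]1C[C@]23O[C@@H]1O[C@H](COC(=O)c2ccccc2)[C@@H](O)[C@H](O)[C@H]1O`, is built on a different core but bears the same benzoyl ester on its sugar; in this assay compound 2 gives > 100000 nM, again a limit of the assay rather than a number. Among the compounds with values here, compound 3, `CC(C)c1ccc(CO[C@@H]2O[C@H](CO[C@@H]3O[C@@H](C)[C@H](O)[C@@H](O)[C@H]3O)[C@@H](O)[C@H](O)[C@H]2O)cc1`, a 4-isopropylbenzyl glycoside of a disaccharide, is the only member with a measured number: in this assay compound 3 gives 97500 nM. Compound 3 thus stands alone with a value, and the other two sit at the limit of > 100000 nM in this assay, at which 2 of the 3 values shown sit.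

Compound 4, `CC(C)=CCC/C(C)=C/C(=O)O[C@@H]1O[C@H](CO[C@@H]2O[C@@H](C)[C@H](O)[C@@H](O)[C@H]2O)[C@@H](O)[C@H](O)[C@H]1O`, differs from compound 3 in one place: (2,6-dimethylhepta-1,5-dien-1-yl)carbonyl in place of 4-isopropylbenzyl on an oxygen on a saturated carbon. Within the data shown here, no step between two measured compounds is available to calibrate this change, and the two limits say only that the benzoyl esters of compound 1 and compound 2 fall outside the range of the assay. The step of a 1.0-fold higher number from compound 3 to compound 4 (0.01 log units; within the scatter) is therefore expected to be small, not beyond the usual scatter, with a fair chance that compound 4 returns only a limit. Compound 4 is estimated at 100000 nM, with a range from 40000 nM to 300000 nM.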

Compound 4, half-maximal inhibitory concentration: > 100000 nM
Compound 4 ended at the assay's limit; the forecaster's own chance of this, stated with the estimate: 55%; the middle value sits exactly at the limit.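

In this assay, within the data shown here, putting (2,6-dimethylhepta-1,5-dien-1-yl)carbonyl in place of 4-isopropylbenzyl on this oxygen gives an at least 1.0-fold higher number from compound 3 to compound 4 (0.01 log units; that floor lies within the scatter), the first step between two compounds that differ in one place. In this assay compound 4 gives > 100000 nM, which is a limit of the assay and not a number, so the step gives only a floor and its true size cannot be read. The exchange of a group with a six-membered aromatic ring for an open chain with no ring therefore brings no lower number at this position, and the series now rests almost entirely at one limit: the limit of > 100000 nM in this assay, at which 3 of the 4 values shown sit.

As far as these compounds go, it remains open how far compound 4 lies beyond its limit, and so whether this exchange has any real effect on the read-out. Also open, from the compounds shown here alone, is whether a different group on this oxygen, such as a chain carrying an amine or a carboxylic acid, would bring the number clearly down from where compound 3 stands.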